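Working notes: methyl in place of nitro

A few compounds are considered here, and "the series" means these few. Any claim that something is new, unique, unknown or untested is made for them only; others in the source may bear on it.

Of the compounds shown here, two have been read so far in a functional assay on COLO 205 cells (Homo sapiens) for inhibition, read by MTT assay, with a stated time of 48 h (on this read-out lower numbers stand for stronger inhibition and higher numbers for weaker inhibition), and only one gives a number. Compound 1 `COc1cc(C(=O)/C=C/c2cc(O)ccc2O)cc(OC)c1OC` returns > 100000 nM which is a limit and not a number. Compound 2 `COc1cc(C(=O)/C=C/c2ccc([N+](=O)[O-])cc2)cc(OC)c1OC` gives 43000 nM and so stands as the only numerical reference point in the series. Compound 3 `COc1cc(C(=O)/C=C/c2ccc(C)cc2)cc(OC)c1OC` is still unread. It carries methyl in place of nitro on an aromatic carbon, para to a large group methyl in place of nitro on an aromatic carbon and is otherwise unchanged. Going by the values given here, no measured pair differs in one place only, so the series offers no direct precedent for this change. The expected step of a 1.2-fold higher number from compound 2 to compound 3 (0.07 log units; within the scatter) is small, within the usual scatter or slightly toward weaker inhibition. The anchor for that expectation is compound 2 at 43000 nM and nothing closer. For compound 3 the estimate is 50000 nM with 18000 nM to 100000 nM as the expected range.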

Compound 3, half-maximal inhibitory concentration: 41500 nM
The estimate for compound 3 lay 1.2-fold (0.08 log units) above the measured number, and the stated range covers the measured number.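

In this assay, going by these compounds alone, the first one-place comparison at this position gives a 1.0-fold lower number from compound 2 to compound 3 (0.02 log units; within the scatter). On an aromatic carbon, para to a large group, methyl in place of nitro therefore leaves the read-out within the scatter, even though the two groups differ in heavy atoms and hydrogen-bond acceptors. With 4-methylphenyl in place of 2,5-dihydroxyphenyl, the series shows an at least 2.4-fold lower number from compound 1 to compound 3 (0.38 log units; beyond the scatter), and compound 1 holds a limit and not a number, so the full size of that step stays open: the limit of > 100000 nM in this assay, at which 1 of the 3 values shown sits.

Going by these compounds, whether other groups at this position, such as an amine, a carboxylic acid or a longer chain, would also leave the read-out unmoved remains open. The step from compound 1 to compound 3 also cannot separate the contribution of each hydroxyl group from that of the entering methyl.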